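Chain change: 3-fluoropropyl to 2-methoxyethyl

The source may report more compounds than this note shows. Statements on the series, on what has been measured and on what is new or still open speak of the compounds shown alone.

Going by the values given here, compound 2 `CN1C(=S)[C@@H](NC(=O)c2nc(Cc3ccccc3)n(CCCF)n2)COc2ccccc21` gives 4760 nM in a functional assay on HT-29 cells (Homo sapiens) for inhibition, read by luminescence and CellTiter-Glo, with a stated time of 24 h (on this read-out lower numbers stand for an effect already at smaller amounts and higher numbers for an effect only at larger amounts of compound), and holds the higher of the two numbers so far, against compound 1 `CCCn1nc(C(=O)N[C@H]2COc3ccccc3N(C)C2=S)nc1Cc1ccccc1` at 288 nM in the same read-out. Next is compound 3 `COCCn1nc(C(=O)N[C@H]2COc3ccccc3N(C)C2=S)nc1Cc1ccccc1`, with the difference methoxy in place of fluoromethyl on a saturated chain carbon, two bonds along the chain from an aromatic nitrogen in the chain: methoxy in place of fluoromethyl on a saturated chain carbon, two bonds along the chain from an aromatic nitrogen. Among the compounds with values here, the only measured step on this chain is large (a 17-fold higher number from compound 1 to compound 2 (1.22 log units; beyond the scatter)) and shows that one replacement here can shift the number strongly. Within the data shown here, no measured compound carries methoxy, so the size of the next step remains uncertain. Compound 3 is expected to fall between compound 1 and compound 2, with a moderate expected step toward a lower number (a 2.8-fold lower number from compound 2 to compound 3 (0.45 log units; beyond the scatter)). For compound 3 the estimated value is 1700 nM (expected range 500 nM to 6000 nM).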

Compound 3, half-maximal effective concentration: 566 nM
Compound 3: middle estimate off by 3.0-fold (0.48 log units), on the high side; measured number inside the range.
By their numbers in this assay, from the lowest: compounds 1 and 3 (each within the scatter of the next); then compound 2.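

In this assay the 2-methoxyethyl chain of compound 3 takes back most of what the 3-fluoropropyl chain lost (an 8.4-fold lower number from compound 2 to compound 3 (0.92 log units; beyond the scatter)), so the exchange of fluoromethyl for methoxy at this place carries a clear effect on the number. Against the plain propyl chain the change reads differently (a 2.0-fold higher number from compound 1 to compound 3 (0.29 log units; within the scatter)): compound 1 and compound 3 cannot be told apart, and among these three chains only the 3-fluoropropyl chain of compound 2 stands apart from the others. Nothing measured on these compounds accounts for the difference between the fluorinated and the methoxy chain.

As far as these compounds go, whether this tolerance reaches further stays open. An amine or a longer ether chain in this place could show how much variation the position accepts before the number rises.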